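The compounds below may be only part of what the source reports. "The series", "measured", "known", "first", "only" and "open" are said of these compounds alone.

Working notes on the phenoxyphenyl pyrazole series. Compound 1 `O=C(CCl)N1CCCC(n2nc(-c3ccc(Oc4ccccc4)cc3)cc2CO)C1` carries a chloroacetamide on a piperidine and a hydroxymethyl on the shared core; in a functional assay on Z-138 cells (Homo sapiens) for inhibition, read by luminescence and CellTiter-Glo, with a stated time of 72 h (a lower number here means a stronger inhibitor, a higher number a weaker inhibitor), compound 1 gives 400 nM. Compound 2 `C=CC(=O)Nc1cccc(Cn2nc(-c3ccc(Oc4ccccc4)cc3)cc2C(=O)OCC)c1` moves the warhead onto a benzyl substituent as an acrylamide and carries an ethyl ester on the core; in this assay compound 2 gives 7800 nM, the highest of the two numbers shown, a long way from compound 1 and well beyond the scatter. Compound 3 `C=CC(=O)Nc1ccc(Cn2nc(-c3ccc(Oc4ccccc4)cc3)cc2C(=O)O)cc1` keeps the acrylamide on the benzyl group but carries the free acid on the core. In this assay compound 3 gives > 60000 nM, which is a limit of the assay and not a number, (the limit of > 60000 nM in this assay, at which 1 of the 3 values shown sits). Compound 3 differs from compound 2 in two places, so neither change can be separated from the other on these numbers.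

Compound 4 `C/C=C/C(=O)Nc1ccc(Cn2nc(-c3ccc(Oc4ccccc4)cc3)cc2C(=O)OCC)cc1` is the next case: 4-(((prop-1-en-1-yl)carbonyl)amino)phenyl in place of 3-((vinylcarbonyl)amino)phenyl on a saturated chain carbon bound to an aromatic nitrogen. For the measured compounds named here, no step between measured compounds covers this change. The crotonamide variant of the acrylamide and the shifted position both lack a clean comparison; the only neighbouring data point, compound 3, sits at a limit. The expectation is a step toward weaker inhibition, a 1.9-fold higher number from compound 2 to compound 4 (0.28 log units; within the scatter), with a fair chance that only a limit is returned. Compound 4 is estimated at 15000 nM, within 4000 nM to 60000 nM.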

Compound 4, half-maximal inhibitory concentration: > 60000 nM
Compound 4: only a limit was reported; the forecaster's own chance of this, stated with the estimate: 25%; middle value at least 4.0-fold (0.60 log units) away from the limit.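

With the ethyl ester held on the shared core, 4-(((prop-1-en-1-yl)carbonyl)amino)phenyl in place of 3-((vinylcarbonyl)amino)phenyl on a saturated chain carbon bound to an aromatic nitrogen gives, in this assay, an at least 7.6-fold higher number from compound 2 to compound 4 (0.88 log units; beyond the scatter). For the compounds shown here, this is the first step that changes one place only, and it shows that the readout at this position responds to the change in this substituted phenyl group, beyond the scatter. The value of compound 4 is a limit of the assay and not a number, so the step gives only a lower bound on the size of the change: the limit of > 60000 nM in this assay, at which 2 of the 4 values shown sit.

The change at this place combines two things, the position of the amide on the phenyl ring and the extra methyl on the alkene, and these two cannot be separated on the compounds shown. From the compounds shown here alone, it also remains open whether a different group on this phenyl amide, such as a dimethylamino-terminated butenamide chain, or a primary amide in place of the ethyl ester on the core, would give a measurable number rather than a limit.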